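Removing an Acetyl Group from a Coumarin Furoxan Hybrid

This account rests on a few compounds, and the source may have more. Where it says the series, first, only, none or still open, it means among the compounds named here.

Compound 1, `COc1cc2cc(NC(C)=O)c(=O)oc2cc1OCCCOc1no[n+]([O-])c1S(=O)(=O)c1ccccc1`, was tested in an ADME assay on L02 cells (Homo sapiens) for cytotoxicity, read by MTT assay, with a stated time of 48 h (on this read-out lower numbers stand for stronger inhibition and higher numbers for weaker inhibition), where compound 1 gives 8360 nM. Compound 3, `COc1cc2cc(N)c(=O)oc2cc1OCCCOc1no[n+]([O-])c1S(=O)(=O)c1ccccc1`, differs from it by hydrogen in place of acetyl on a nitrogen on an aromatic ring. In this assay compound 3 gives 9160 nM, so the change gives a 1.1-fold higher number from compound 1 to compound 3 (0.04 log units; within the scatter). Among the measured compounds shown here, this single exchange is the only kind of change that is repeated among the compounds here, and it appears a second time in a pair whose first member has already been measured.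

That first member is compound 2, `COc1cc2cc(NC(C)=O)c(=O)oc2cc1OCCCCOc1no[n+]([O-])c1S(=O)(=O)c1ccccc1`. How its core differs from the core of compound 1 is not broken down here. In this assay compound 2 gives 9190 nM; this number and that of compound 3 lie within the scatter of each other, as do the numbers of compound 2 and compound 1.

Compound 4, `COc1cc2cc(N)c(=O)oc2cc1OCCCCOc1no[n+]([O-])c1S(=O)(=O)c1ccccc1`, has not yet been measured. It differs from compound 2 by hydrogen in place of acetyl on a nitrogen on an aromatic ring. The place of the change is described in the same words as for the change from compound 1 to compound 3, so this is the same change on a different core.

For compound 4 the step expected in this assay is a 1.1-fold higher number from compound 2 to compound 4 (0.04 log units; within the scatter), beside the earlier 1.1-fold higher number from compound 1 to compound 3 (0.04 log units; within the scatter), resting on that single measured pair and on the closeness of all three measured numbers. The value estimated for compound 4 is 10000 nM, expected to fall between 5000 nM and 20000 nM.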

Compound 4, half-maximal inhibitory concentration: 8630 nM
Compound 4: the middle estimate sits 1.2-fold (0.06 log units) above what was measured; measured number inside the range.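

In this assay, replacing acetamido with amino on the core of compound 2 gives a 1.1-fold lower number from compound 2 to compound 4 (0.03 log units; within the scatter). Set beside the same exchange on the core of compound 1, the two steps point in opposite directions, but the gap between them is no larger than repeated measurements would produce: the same change on two cores in this assay, a 1.1-fold higher number (0.04 log units; within the scatter) from compound 1 to compound 3 and a 1.1-fold lower number (0.03 log units; within the scatter) from compound 2 to compound 4, 1.2-fold (0.07 log units) apart, within the scatter of two such steps. This shows that, across these two pairs, the exchange leaves the number within the scatter on both cores, so the small result seen on one core also held on the other, but it does not show a real effect of the exchange that carries over, and two pairs say nothing about cores beyond these.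

The compounds shown have only a hydrogen or an acetyl group on that nitrogen, so it remains open whether a larger group there, such as benzoyl, or a simple methyl, would shift the number beyond the scatter. From the compounds shown here alone, it also remains open whether the exchange would stay this small on a core with a longer chain, or whether a step beyond the scatter would appear in a measurement other than this one.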